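The source may report more compounds than this note shows. Statements on the series, on what has been measured and on what is new or still open speak of the compounds shown alone.

Measured so far:
Compound 1 `COc1ncnc2c1c(-c1ccccc1)cn2[C@@H]1O[C@H](CO)[C@@H](O)[C@H]1O` — in a functional assay on CCRF-CEM cells (Homo sapiens), read by MTT assay, with a stated time of 72 h (a lower number here means a stronger inhibitor, a higher number a weaker inhibitor), compound 1 gives only a limit, > 20000 nM (the limit of > 20000 nM in this assay, at which 1 of the 3 values shown sits).
Compound 2 `COc1ncnc2c1c(-c1cc3ccccc3o1)cn2[C@@H]1O[C@H](CO)[C@@H](O)[C@H]1O` — compound 2 gives 5370 nM.
Compound 3 `COc1ncnc2c1c(-c1ccoc1)cn2[C@@H]1O[C@H](CO)[C@@H](O)[C@H]1O` — compound 3 gives 110 nM.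

Compound 3 stands lowest of the two numbers; the nearest is compound 2, with a 49-fold lower number from compound 2 to compound 3 (1.69 log units; beyond the scatter). The other steps, an at least 3.7-fold lower number from compound 1 to compound 2 (0.57 log units; beyond the scatter) and an at least 180-fold lower number from compound 1 to compound 3 (2.25 log units; beyond the scatter), also change the aryl group on the aromatic carbon, not the methoxy.

Compound 4 `CN(C)c1ncnc2c1c(-c1ccoc1)cn2[C@@H]1O[C@H](CO)[C@@H](O)[C@H]1O` differs from compound 3 only thus: dimethylamino in place of methoxy on an aromatic carbon. For the measured compounds named here, no measured step alters this position, so no precedent bears on it; the step is expected to stay within the scatter, a 1.4-fold higher number from compound 3 to compound 4 (0.13 log units; within the scatter). Compound 4 is therefore estimated at 150 nM, within 40 nM to 600 nM.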

Compound 4, half-maximal inhibitory concentration: 13300 nM
The estimate for compound 4 lay 89-fold (1.95 log units) below the measured number, outside the stated range (above it).
By their numbers in this assay, from the lowest: compound 3; then compound 2; then compound 4. At a limit, above all of these: compound 1.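

With furan-3-yl held fixed, the aromatic carbon next to the ring nitrogen proves highly sensitive in this assay: dimethylamino in place of methoxy gives a 120-fold higher number from compound 3 to compound 4 (2.08 log units; beyond the scatter). The aryl group is therefore not the only site on the shared core that moves the number strongly. Nothing at hand accounts for this step.

Going by these compounds, whether the step carries over to the phenyl or 1-benzofuran-2-yl compounds stays open. Also open, on these data alone, is how a primary amine, methylamino, ethoxy or a plain methyl would read at this position.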